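Meta-chloro on the cinnamyl amide: compound 3 to compound 4

A few compounds are considered here, and "the series" means these few. Any claim that something is new, unique, unknown or untested is made for them only; others in the source may bear on it.

Working notes on a small amide series sharing one core. In an assay on CHO cells for displacement of a labelled ligand from adenosine receptor A1 (Homo sapiens), read by scintillation counting, with a stated time of 90 min (on this read-out higher numbers stand for weaker inhibition and lower numbers for stronger inhibition), compound 1 `COc1cccc(CCCC(=O)Nc2nc3ccccc3c(=O)s2)c1` gives 214 nM. For compound 2 `CN(C(=O)CCCc1ccccc1)c1nc2ccccc2c(=O)s1` the entry in this assay reads "not determined" (no result reported), so no number is available for it. Compound 3 `O=C(C/C=C/c1ccccc1)Nc1nc2ccccc2c(=O)s1` gives 822 nM in this assay, the highest of the two numbers available; compound 1 stands beyond the scatter below it. Among the compounds with values here, no pair differing in a single place has been measured, so no step size is known for this series. The next compound, compound 4 `O=C(C/C=C/c1cccc(Cl)c1)Nc1nc2ccccc2c(=O)s1`, differs from compound 3 as follows: chloro in place of hydrogen on an aromatic carbon. Within the data shown here, with no matching step on record, the change from compound 3 to compound 4 is expected to stay within the scatter or bring a small gain, a 1.4-fold lower number from compound 3 to compound 4 (0.14 log units; within the scatter). Compound 4 is therefore estimated at 600 nM, in the range 200 nM to 1800 nM.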

Compound 4, inhibition constant: 562 nM
For compound 4 the middle estimate is 1.1-fold (0.03 log units) above the measured one, within the range that was stated.
By their numbers in this assay, from the lowest: compound 1; then compounds 4 and 3 (each within the scatter of the next).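

In this assay, this is the series' first step between compounds differing in one place, and it measures chloro in place of hydrogen on an aromatic carbon, meta to a large group: a 1.5-fold lower number from compound 3 to compound 4 (0.17 log units; within the scatter). Phenyl to 3-chlorophenyl therefore gives no change that can be told from the scatter. No measured evidence bearing on this result is available.

From the compounds shown here alone, whether an amine or a carboxylic acid at this carbon would give a step beyond the scatter remains open. The effect of chloro on the other carbons of this ring is also unknown.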